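This account rests on a few compounds, and the source may have more. Where it says the series, first, only, none or still open, it means among the compounds named here.

Measured so far in a functional assay on Jurkat cells (Homo sapiens) for antiproliferative activity, read by MTT assay, with a stated time of 72 h; on this read-out higher numbers stand for weaker inhibition and lower numbers for stronger inhibition:
- compound 1 `O=C1C[C@H]2O[C@H](Cc3ccccc3)[C@H](OCc3ccccc3)[C@H]2O1` gives 1010 nM
- compound 2 `O=C1C[C@@H]2O[C@H]3[C@H](c4ccccc4)c4ccccc4CO[C@H]3[C@@H]2O1` gives 18500 nM
- compound 3 `O=C1C[C@H]2O[C@H](Cc3ccccc3)[C@H](O)[C@H]2O1` gives 2520 nM

Compound 2 stands highest of the three, and its number lies beyond the scatter from both others. Compound 4 `O=C1C[C@H]2O[C@@H]3[C@@H](c4ccccc4)c4ccccc4CO[C@@H]3[C@H]2O1` is its mirror image: the two compounds have the same atoms and bonds and differ only in configuration as drawn: 5 of 5 stereo elements differ (all stereocentres are inverted: mirror images); a stereocentre at a saturated ring carbon is drawn S in compound 2 and R in compound 4; a stereocentre at a saturated ring carbon is drawn S in compound 2 and R in compound 4; a stereocentre at a saturated ring carbon is drawn R in compound 2 and S in compound 4; a stereocentre at a saturated ring carbon is drawn R in compound 2 and S in compound 4. Going by the values given here, no mirror-image pair has been measured, so no step bears directly on this change. Among the compounds with values here, the one measured step, a 2.5-fold higher number from compound 1 to compound 3 (0.40 log units; beyond the scatter), concerns a benzyl group and serves only as a rough gauge of size. With compound 2 at 18500 nM, the top of the measured range, a modest shift toward a lower number is expected, with wide uncertainty. The expected step is a 2.6-fold lower number from compound 2 to compound 4 (0.42 log units; beyond the scatter). Compound 4 is estimated at 7000 nM, with an expected range of 1200 nM to 35000 nM.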

Compound 4, half-maximal inhibitory concentration: 74 nM
For compound 4 the middle estimate is 95-fold (1.98 log units) above the measured one, and the stated range ends above it.
By their numbers in this assay, from the lowest: compound 4; then compound 1; then compound 3; then compound 2.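

In this assay, going by these compounds alone, the mirror-image pair gives a 250-fold lower number from compound 2 to compound 4 (2.40 log units; beyond the scatter), the first reading of what configuration alone does, and a far larger step than the one seen on removing the benzyl group. The whole step can be assigned to configuration, because nothing else changes: the fact that compounds 2 and 4 differ only in the configuration as drawn. The earlier compounds shown here, which differ in substituents, could not show this.

Still open, on these data alone, is which of the inverted stereocentres carries the step. Also open, as far as these compounds go, is whether an amine or a carboxylic acid on the shared core would keep the number near that of compound 4, 74 nM.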